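The compounds below may be only part of what the source reports. "The series", "measured", "known", "first", "only" and "open" are said of these compounds alone.

Measured so far in a functional assay on the whole organism with Mus musculus as the target (on this read-out lower numbers stand for an effect already at smaller amounts and higher numbers for an effect only at larger amounts of compound), are three compounds:
compound 1 (`Cc1c(C)c2c(c(C)c1N)CC(C)(C)O2`) gives 7.8 mg/kg
compound 2 (`CC1(C)Cc2cc(N)ccc2O1`) gives > 100 mg/kg as a limit
compound 3 (`Cc1c(C)c2c(c([N+](=O)[O-])c1N)CC(C)(C)O2`) gives > 100 mg/kg as a limit

Compound 1 is the only one of the three with an actual number in this assay and the other two stand at the limit of > 100 mg/kg in this assay, at which 2 of the 3 values shown sit, without one. The next compound is compound 4 (`Cc1c(N)c(C)c2c(c1CC(C)C)OC(C)(C)C2`), which keeps the core of compound 1. Its difference from compound 1 is isopropyl in place of hydrogen on a saturated chain carbon bound to an aromatic carbon and this is isopropyl in place of hydrogen on a saturated chain carbon bound to an aromatic carbon, or methyl to isobutyl when cut one bond further out.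

Among the measured compounds shown here, the only measured step from compound 1 is an at least 12-fold higher number from compound 1 to compound 3 (1.10 log units; beyond the scatter) with nitro in place of methyl on an aromatic carbon. That large step shows that a single change to compound 1 can reach the limit, but it concerns an aromatic carbon and not a saturated chain carbon, so it bears on compound 4 only loosely. For the measured compounds named here, no measured step adds a chain of this kind. The expectation is therefore no shift beyond the scatter, with more room for loss than for gain, and the estimated step is a 1.5-fold higher number from compound 1 to compound 4 (0.19 log units; within the scatter) in this assay as a cautious guess. For compound 4 the expected value is 12 mg/kg with an estimated range from 3 mg/kg to 50 mg/kg.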

Compound 4, dose for 50% inhibition: 13.3 mg/kg
For compound 4 the middle estimate is 1.1-fold (0.04 log units) below the measured one, within the range that was stated.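

In this assay, the change from methyl to isobutyl gives a 1.7-fold higher number from compound 1 to compound 4 (0.23 log units; within the scatter), so this first change at a saturated chain carbon bound to an aromatic carbon brings no shift beyond the scatter. The earlier single change to compound 1, an at least 12-fold higher number from compound 1 to compound 3 (1.10 log units; beyond the scatter), concerned an aromatic carbon, so it said nothing about this place, where isopropyl can now be added to the methyl group with the effect still in the same range. Compound 4 also has an actual number and does not join the compounds that stand at a limit, which is a limit and not a number: the limit of > 100 mg/kg in this assay, at which 2 of the 4 values shown sit.

With only methyl and isobutyl shown at this place, it stays open how a longer chain, a phenyl ring, an amine or a carboxylic acid would read there, and whether the flat result for isobutyl would hold for any of them. Compound 2 differs from compound 1 in more than one place, so the compounds shown also leave open what each methyl group on the aromatic carbons contributes on its own.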